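A few compounds are considered here, and "the series" means these few. Any claim that something is new, unique, unknown or untested is made for them only; others in the source may bear on it.

In an assay on Sf9 cells for inhibition of histone deacetylase 11 (Homo sapiens), read by fluorescence, tested at 0.5 uM (on this read-out lower numbers stand for less inhibition and higher numbers for more inhibition at the one concentration tested (going by the name of the read-out)), compound 2 `O=C(NO)c1ccc(-c2cn([C@H]3C[C@@H](C(=O)O)N(Cc4ccccc4)C3)nn2)cc1` gives only a limit, < 10%. Compound 1 `O=C(NO)c1ccc(-c2cn([C@@H]3C[C@@H](C(=O)O)N(Cc4ccccc4)C3)nn2)cc1` likewise gives only a limit, < 10%. Compound 3 `O=C(NO)c1ccc(-c2cn([C@H]3C[C@@H](C(=O)O)N(CCCc4ccccc4)C3)nn2)cc1` gives 14%. The step that the two limits leave unreadable from compound 1 to compound 2 cannot be sized because of the limit of < 10% in this assay, at which 2 of the 3 values shown sit, and the step of a number at least 4 percentage points higher from compound 2 to compound 3 (that floor lies within the scatter) stays within the scatter. Compound 4 `O=C(/C=C/c1cn([C@H]2C[C@@H](C(=O)O)N(Cc3ccccc3)C2)nn1)NO` differs from compound 2 in a different place: 2-(hydroxycarbamoyl)ethenyl in place of 4-(hydroxycarbamoyl)phenyl on an aromatic carbon. Neither measured step touches the hydroxamic acid side of the shared core, so neither bears on this change, and the two that exist show at most movement within the scatter. Compound 4 is therefore expected to stay near the limit, with an estimated step of a number no lower from compound 2 to compound 4 (the limit leaves the size open) that is not beyond the scatter. The expected value for compound 4 is 10%, ranging from 0% to 25%.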

Compound 4, a percentage reported as inhibition, at one concentration (the size of the read-out at that concentration, not a potency): 23%
Compound 4: the middle estimate sits 13 percentage points below what was measured, and the stated range covers the measured number.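

In this assay the side bearing the hydroxycarbamoyl group, untouched by the earlier steps, responds: 2-(hydroxycarbamoyl)ethenyl in place of 4-(hydroxycarbamoyl)phenyl gives a number at least 13 percentage points higher from compound 2 to compound 4 (beyond the scatter) and is the only step shown to clear the scatter. The entering group has no ring, so inhibition at this level does not need the six-membered aromatic ring at this position. As far as these compounds go, the full size stays open, since compound 2 sits at a limit: the limit of < 10% in this assay, at which 2 of the 4 values shown sit. Still open, from the compounds shown here alone, is whether a saturated ethyl chain or a longer chain carrying the hydroxycarbamoyl group would do the same. Also open, going by these compounds, is whether the double bond or the loss of the ring accounts for the step.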